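The source may report more compounds than this note shows. Statements on the series, on what has been measured and on what is new or still open speak of the compounds shown alone.

Measured compounds:
compound 1 `COc1ccc2ccc(=O)oc2c1C1=NN(C(C)=O)C(c2cccs2)C1` with 75 nM
compound 2 `COc1ccc2ccc(=O)oc2c1C1=NN(c2ccccc2)C(c2ccc(SC)cc2)C1` with 78 nM

In a functional assay on HepG2 cells (Homo sapiens) for cytotoxicity, read by MTT assay, with a stated time of 72 h (on this read-out higher numbers stand for weaker inhibition and lower numbers for stronger inhibition), compound 1 gives 75 nM, and in this assay compound 2 gives 78 nM. Compound 2 stands level with compound 1: the two values sit within the usual scatter of each other, so nothing separates them. Within the data shown here, the two compounds differ in more than one place, so no single step between them can be read.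

Compound 3 `COc1ccc2ccc(=O)oc2c1C1=NN(c2ccccc2)C(c2cccs2)C1` is not yet measured. It differs from compound 2 by thiophen-2-yl in place of 4-(methylsulfanyl)phenyl on a saturated ring carbon. Among the measured compounds shown here, no measured pair isolates this change. For the measured compounds named here, the only guidance is that compound 1, which also carries thiophen-2-yl on this saturated ring carbon, gives 75 nM, a number within the scatter of compound 2.

Compound 3 is therefore expected to stay close to compound 2, with a step of a 1.0-fold higher number from compound 2 to compound 3 (0.01 log units; within the scatter) that is not expected to exceed the scatter. The estimate for compound 3 is 80 nM, within a range from 30 nM to 220 nM.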

Compound 3, half-maximal inhibitory concentration: 15 nM
The estimate for compound 3 lay 5.3-fold (0.73 log units) above the measured number, and the stated range ends above it.
By their numbers in this assay, from the lowest: compound 3; then compounds 1 and 2 (each within the scatter of the next).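

In this assay the saturated ring carbon proves sensitive to its substituent: with phenyl held on the ring nitrogen, thiophen-2-yl in place of 4-(methylsulfanyl)phenyl gives a 5.2-fold lower number from compound 2 to compound 3 (0.72 log units; beyond the scatter), a change the earlier pair could not isolate. The amine nitrogen in the ring also matters: with thiophen-2-yl held, phenyl in place of acetyl gives a 5.0-fold lower number from compound 1 to compound 3 (0.70 log units; beyond the scatter), so the level values of compound 1 and compound 2 concealed two separate single-place steps. Nothing measured here accounts for either step.

Among these compounds, the step on the saturated ring carbon is seen only with phenyl on the amine nitrogen, so whether it persists with acetyl there remains open. Also open, going by these compounds, is how furan-2-yl on that carbon, or a carboxylic acid on the phenyl group, would read in this assay.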